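The source may report more compounds than this note shows. Statements on the series, on what has been measured and on what is new or still open speak of the compounds shown alone.

In an ADME assay on L6 cells (Rattus norvegicus) for cytotoxicity (on this read-out lower numbers stand for stronger inhibition and higher numbers for weaker inhibition), two amides sharing one core have been measured so far. Compound 1 (`O=C(Nc1c(O)cccc1-c1nc2c(C(=O)O)cccc2o1)c1ccccn1`) gives 30600 nM, and compound 2 (`O=C(Nc1c(O)cccc1-c1nc2c(C(=O)O)cccc2o1)c1cccnc1`) gives 240000 nM, the higher of the two numbers and so the weaker inhibition. The next structure, compound 3 (`O=C(Nc1c(O)cccc1-c1nc2c(C(=O)O)cccc2o1)c1ccccc1`), carries phenyl in place of pyridin-3-yl on a carbonyl carbon. Among the compounds with values here, only one measured step bears on this change, and it lies at the same place: a 7.8-fold higher number from compound 1 to compound 2 (0.89 log units; beyond the scatter), a modest move beyond the scatter, with pyridin-3-yl in place of pyridin-2-yl. Within the data shown here, that step shows that the number in this assay can respond to a change here, but no measured compound carries phenyl, so the direction remains uncertain. With compound 2 at the top of the pair at 240000 nM, a fall of similar or somewhat smaller size is expected rather than a further rise. The expected move is a 3.4-fold lower number from compound 2 to compound 3 (0.54 log units; beyond the scatter). For compound 3 the estimated value is 70000 nM, with an expected range of 20000 nM to 220000 nM.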

Compound 3, half-maximal inhibitory concentration: > 240000 nM
Compound 3 ended at the assay's limit; the forecaster's own chance of this, stated with the estimate: 15%; at least 3.4-fold (0.53 log units) between middle value and limit.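

In this assay compound 3 gives > 240000 nM, a limit and not a number, and the read-out ends there: the limit of > 240000 nM in this assay, at which 1 of the 3 values shown sits. Phenyl in place of pyridin-3-yl on a carbonyl carbon gives a number no lower from compound 2 to compound 3 (the limit leaves the size open), so this change brings no lower number, though the size of the step cannot be read. Set against the pyridin-2-yl amide, the result is an at least 7.8-fold higher number from compound 1 to compound 3 (0.89 log units; beyond the scatter), which leaves compound 1 as the only one of the three with a number lower than the others by more than the scatter, and shows that removing the ring nitrogen altogether does not restore the lower number seen with pyridin-2-yl.

On these data alone, how far compound 3 lies past the limit stays open, so phenyl and pyridin-3-yl cannot be put in order at this position. Also open is how far the number can fall on this carbonyl carbon: an amine or a carboxylic acid on the pyridin-2-yl ring, or a piperidine ring or a short alkyl chain in its place, does not appear among these compounds.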